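The source may report more compounds than this note shows. Statements on the series, on what has been measured and on what is new or still open speak of the compounds shown alone.

Compound 1 `O=C1O[C@@H](CN2CCC(c3ccc(F)cc3)CC2)CN1c1ccc(-n2cc(-c3ccccn3)cn2)c(F)c1`; in an ADME assay on HEK293-A cells (Homo sapiens) for cytotoxicity, read by MTT assay, with a stated time of 48 h (on this read-out higher numbers stand for weaker inhibition and lower numbers for stronger inhibition), compound 1 gives > 400 ug/mL, which is a limit of the assay, not a number.
Compound 2 `O=C1CNC(=O)N1C[C@H]1CN(c2ccc(-n3cc(-c4ccccn4)cn3)c(F)c2)C(=O)O1`; in this assay compound 2 gives > 400 ug/mL, again a limit of the assay.
Compound 3 `O=C1O[C@@H](Cn2ccnc2)CN1c1ccc(-n2cc(-c3ccccn3)cn2)c(F)c1`; in this assay compound 3 gives > 400 ug/mL, also a limit of the assay.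

Compound 3 therefore stands at the same limit as both other compounds, and nothing among the numbers sets it apart. Among the compounds with values here, the only single-point step among the measured compounds, a step that the two limits leave unreadable from compound 2 to compound 3, cannot be read, since both ends are limits.

Compound 4 `O=C1O[C@@H](CNC(=O)C(F)(F)F)CN1c1ccc(-n2cc(-c3ccccn3)cn2)c(F)c1` differs from compound 3 by ((trifluoromethyl)carbonyl)amino in place of 1H-imidazol-1-yl on a saturated chain carbon bound to a saturated ring carbon. Within the data shown here, no measured step gives a readable size for this kind of exchange. What the data do show is the limit of > 400 ug/mL in this assay, at which 3 of the 3 values shown sit, so no shift beyond the scatter is expected from compound 3 to compound 4, and the step of a number no higher from compound 3 to compound 4 (the limit leaves the size open) is expected to be flat. Compound 4 is thus expected to give 400 ug/mL in this assay, with a range from 200 ug/mL to 800 ug/mL, most likely reported again only as a limit.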

Compound 4, half-maximal inhibitory concentration: > 400 ug/mL
Compound 4 was reported as a limit; the forecaster's own chance of this, stated with the estimate: 85%; the middle value sits exactly at the limit.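

The steps from compound 2 and from compound 3 to compound 4 cannot be read, since both ends of each step are limits of the assay, not numbers. The compounds shown leave open what concentration, if any, would give half-maximal inhibition in this assay, and whether exchanging these groups changes it: the limit of > 400 ug/mL in this assay, at which 4 of the 4 values shown sit.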